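A few compounds are considered here, and "the series" means these few. Any claim that something is new, unique, unknown or untested is made for them only; others in the source may bear on it.

Measured compounds:
Compound 1, `O=C(Nc1cc(-c2ccccc2)nn1-c1ccccc1)c1ccccc1`, in an assay on HEK293 cells for displacement of a labelled ligand from metabotropic glutamate receptor 5 (Rattus norvegicus) (a higher number here means a weaker inhibitor, a lower number a stronger inhibitor), gives 4180 nM.
Compound 2, `O=C(Nc1cc(-c2ccccc2Cl)nn1-c1ccccc1)c1ccccc1`, in this assay gives > 10000 nM, which is a limit of the assay and not a number.

Compound 2 therefore stands at the weak end of what this assay can report, with only a limit to its name (the limit of > 10000 nM in this assay, at which 1 of the 2 values shown sits). Compound 3, `COc1cccc(-c2cc(NC(=O)c3ccccc3)n(-c3ccccc3)n2)c1`, differs from it in one place: 3-methoxyphenyl in place of 2-chlorophenyl on an aromatic carbon. Among the compounds with values here, only one measured step bears on this change, the one from compound 1 to compound 2, where an at least 2.3-fold higher number from compound 1 to compound 2 (0.37 log units; beyond the scatter). That step went in the weaker direction, so a substituent on the phenyl that sits next to the ring nitrogen has so far only cost binding. On these data alone, a methoxy group at a different position of that phenyl is untested here, and the limit on compound 2 leaves the size of the step uncertain. Compound 3 is expected to land near compound 1 or weaker, at 6000 nM (range 2000 nM to 20000 nM), a step of an at least 1.6-fold lower number from compound 2 to compound 3 (0.22 log units; that floor lies within the scatter) as estimated.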

Compound 3, inhibition constant: 3200 nM
Compound 3: middle estimate off by 1.9-fold (0.27 log units), on the high side; low and high end bracket the measured number.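

Replacing 2-chlorophenyl with 3-methoxyphenyl gives an at least 3.1-fold lower number from compound 2 to compound 3 (0.49 log units; beyond the scatter), so the loss seen with the chloro group does not extend to every substituted phenyl at this position. Relative to the unsubstituted phenyl, methoxy in place of hydrogen gives a 1.3-fold lower number from compound 1 to compound 3 (0.12 log units; within the scatter), so 3-methoxyphenyl is tolerated here without a change that can be read in this assay. The first of these steps remains only a floor, because compound 2 holds a limit of the assay and not a number: the limit of > 10000 nM in this assay, at which 1 of the 3 values shown sits.

Chloro and methoxy differ here both as groups and in their place on the phenyl, so the effects of the two cannot yet be told apart. On these data alone, it also remains open whether an amine or a carboxylic acid on that phenyl would give a clearly stronger inhibitor than compound 1.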